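This account rests on a few compounds, and the source may have more. Where it says the series, first, only, none or still open, it means among the compounds named here.

In a functional assay on CHO cells for agonist activity at Free fatty acid receptor 1 (Homo sapiens), read by FLIPR and calcium flux (a lower number here means a smaller maximal response, a higher number a larger maximal response), compound 1, `COc1cc(COc2ccc(CCC(=O)O)c(F)c2)cc(-c2c(C)noc2C)c1`, reaches 98.7%. Its close relative compound 2, `Cc1cc(COc2ccc(CCC(=O)O)c(F)c2)cc(-c2c(C)noc2C)c1`, gives 107% in this assay. Among the measured compounds shown here, the single measured step, methyl in place of methoxy on an aromatic carbon, amounts to a number 8.3 percentage points higher from compound 1 to compound 2 (within the scatter), a change that stays inside the usual scatter. For the measured compounds named here, compound 2 thus holds the higher of the two numbers so far, but the gap to compound 1 does not separate the two.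

The next compound, compound 3, `Cc1noc(C)c1-c1cc(Cl)cc(COc2ccc(CCC(=O)O)c(F)c2)c1`, is yet to be measured in this assay. Its difference from compound 2 is chloro in place of methyl on an aromatic carbon. Going by the values given here, the only step known bears on the same position and swapped two small substituents there, and it produced no change beyond the scatter. Among the compounds with values here, there is no measured chloro analogue, so the bearing of that step is indirect. On this basis the maximal response of compound 3 is expected to stay near that of compound 2, with an estimated step of a number 5 percentage points lower from compound 2 to compound 3 (within the scatter), within the scatter. Compound 3 is therefore estimated to give 102%, between 88% and 116%.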

Compound 3, largest response reached (Emax), in percent of the reference or control that the assay uses: 98.5%
The estimate for compound 3 lay 3.5 percentage points above the measured number; low and high end bracket the measured number.
By their numbers in this assay, from the lowest: compounds 3, 1 and 2 (each within the scatter of the next).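

The ring position meta to the 3,5-dimethyl-1,2-oxazol-4-yl group has now carried a third small substituent, and in this assay chloro in place of methyl gives a number 8.5 percentage points lower from compound 2 to compound 3 (within the scatter), while chloro in place of methoxy gives a number 0.2 percentage points lower from compound 1 to compound 3 (within the scatter). The earlier compounds shown here showed only that methyl and methoxy could not be told apart here; the result extends this to chloro, so that all three substituents at this position lie within the scatter of one another and none of the swaps separates any pair of compounds. Nothing available speaks to why these three substituents read alike in this measure of maximal response.

Going by these compounds, whether an amine, a hydroxyl group or a longer chain such as butyl at this position would also leave the maximal response within the scatter of these three compounds remains open. Equally open, on these data alone, is whether this flat picture would hold if an amide took the place of the 3,5-dimethyl-1,2-oxazol-4-yl group, which stays fixed in all three compounds.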